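Methoxy to ethoxy on a quinone core

The compounds below may be only part of what the source reports. "The series", "measured", "known", "first", "only" and "open" are said of these compounds alone.

Compound 1 `COc1cc(C)cc2c1C(=O)C=CC2=O`: 15300 nM
Compound 2 `COc1cc(C)c(Cl)c2c1C(=O)C=CC2=O`: 20600 nM

In a functional assay on MCF7 cells (Homo sapiens) for cytotoxicity, read by XTT assay, with a stated time of 24 h (on this read-out higher numbers stand for weaker inhibition and lower numbers for stronger inhibition), compound 2 gives the higher of the two numbers, with compound 1 nearest at 15300 nM; the gap between them is within the scatter, so the two cannot be told apart. For the measured compounds named here, the only measured step, a 1.3-fold higher number from compound 1 to compound 2 (0.13 log units; within the scatter), concerns chloro in place of hydrogen on an aromatic carbon and also lies within the scatter.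

Compound 3 `CCOc1cc(C)c(Cl)c2c1C(=O)C=CC2=O` differs from compound 2 by methyl in place of hydrogen on a saturated chain carbon bound to an oxygen on an aromatic ring. Going by the values given here, no measured step touches this part of the shared core, so nothing here points to a change in either direction. The expectation for compound 3 in this assay is therefore a step of a 1.0-fold lower number from compound 2 to compound 3 (0.01 log units; within the scatter), that is, no step beyond the scatter. Compound 3 is expected to give about 20000 nM, within a range from 8000 nM to 50000 nM.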

Compound 3, half-maximal inhibitory concentration: 40000 nM
Estimate against measurement, compound 3: 2.0-fold (0.30 log units) below; the range from low to high includes it.
By their numbers in this assay, from the lowest: compounds 1, 2 and 3 (each within the scatter of the next, the first and the last beyond it).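

For the compounds shown here, the change from methoxy to ethoxy is the first measured step at this place on the shared core, and in this assay it gives a 1.9-fold higher number from compound 2 to compound 3 (0.29 log units; within the scatter). Adding one methyl on the saturated chain carbon bound to an oxygen on an aromatic ring therefore makes no difference that this read-out can separate from the scatter, although the step is larger than the one seen for chloro. No measurement available here offers an explanation for this result.

A single step cannot show whether a longer chain such as propoxy, or a hydroxy group or an amine in place of the methoxy, would leave the number where it is or shift it. As far as these compounds go, whether the same change would behave alike on compound 1, which carries hydrogen instead of chloro, also stays open.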